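Adding a tert-Butyl Group to a Weak Growth Inhibitor

The compounds below may be only part of what the source reports. "The series", "measured", "known", "first", "only" and "open" are said of these compounds alone.

Of the compounds shown here, three have been measured in a functional assay on MCF7 cells (Homo sapiens) for inhibition, read by CCK-8 assay, with a stated time of 48 h; on this read-out higher numbers stand for weaker inhibition of growth and lower numbers for stronger inhibition of growth. Compound 1 `Cc1ccc(Nc2ncc(Cl)c(Nc3ccccc3C)n2)cc1` gives only a limit of the assay, > 100000 nM. Compound 2 `Cc1ccccc1Nc1nc(Nc2ccccn2)ncc1Cl` gives 31400 nM, and compound 3 `CN1CCN(c2ccc(Nc3ncc(Cl)c(Nc4ccccc4)n3)nc2)CC1` gives 51800 nM, the higher of the two numbers, though its gap to compound 2 lies within the scatter. Going by the values given here, the single measured step, an at least 3.1-fold lower number from compound 1 to compound 2 (0.50 log units; beyond the scatter), concerns a group on a different nitrogen and does not bear on the change followed here. Compound 4 `CN1CCN(c2ccc(Nc3ncc(Cl)c(Nc4ccc(C(C)(C)C)cc4)n3)nc2)CC1` differs from compound 3 by tert-butyl in place of hydrogen on an aromatic carbon. Among the compounds with values here, with no measured step to set the direction, the expected step is a 1.7-fold lower number from compound 3 to compound 4 (0.24 log units; within the scatter). Compound 4 is therefore estimated at 30000 nM, with a range from 8000 nM to 100000 nM.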

Compound 4, concentration for 50% growth inhibition: 12600 nM
Beside the measured number, compound 4's estimate is 2.4-fold (0.38 log units) above it; measured number inside the range.
By their numbers in this assay, from the lowest: compound 4; then compounds 2 and 3 (each within the scatter of the next). At a limit, above all of these: compound 1.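

In this assay, going by these compounds alone, the change from phenyl to 4-(tert-butyl)phenyl brings a 4.1-fold lower number from compound 3 to compound 4 (0.61 log units; beyond the scatter) and is the first change at this place to be read. Within the data shown here, no earlier step touched this ring carbon, so this is the first sign that it can carry a group and that the number responds when it does. This rests on a single pair of compounds.

On these data alone, whether a carboxylic acid or a methoxy group on the same carbon would also lower the number stays open. Nothing shown here explains the fall in the number.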